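The source may hold more compounds than are shown below. What is called first, only, known or untested is meant among the compounds shown, and "the series" means these compounds.

Compound 1 `CCc1cc2ccccc2nc1-c1cc(-c2ccc(F)cc2)no1`: in a functional assay on COLO 205 cells (Homo sapiens) for inhibition, read by MTT assay, with a stated time of 24 h (a lower number here means a stronger inhibitor, a higher number a weaker inhibitor), compound 1 gives > 100000 nM, which is a limit of the assay rather than a number.
Compound 2 `CCCc1cc2ccccc2nc1-c1cc(-c2ccc(F)cc2)no1`: compound 2 gives 50300 nM.
Compound 3 `CCCCc1cc2ccccc2nc1-c1cc(-c2ccc(F)cc2)no1`: compound 3 gives 25300 nM.

Compound 1 stands at the limit of > 100000 nM in this assay, at which 1 of the 3 values shown sits, so for it only a limit is known, and every step that starts from it is itself only a floor. The three measured compounds share one core and differ only in the length of the saturated chain on it. Lengthening that chain gave an at least 1.9-fold lower number from compound 1 to compound 2 (0.29 log units; that floor lies within the scatter) and an at least 3.9-fold lower number from compound 1 to compound 3 (0.59 log units; beyond the scatter), while the step between the two longer chains gave a 2.0-fold lower number from compound 2 to compound 3 (0.30 log units; within the scatter).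

Compound 4 `CCc1cc2ccccc2nc1-c1cc(-c2ccc(C(F)(F)F)cc2)no1` keeps the ethyl chain of compound 1 and changes the other end of the molecule instead: trifluoromethyl in place of fluoro on an aromatic carbon. For the measured compounds named here, none of the measured steps touches that six-membered ring, so they offer no direct guide to what this change does in this assay. With compound 1 sitting at a limit, the expectation is a step of about a number no higher from compound 1 to compound 4 (the limit leaves the size open), that is, none beyond the scatter, and quite possibly another limit. Compound 4 is therefore estimated at 100000 nM, with a range from 40000 nM to 300000 nM.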

Compound 4, half-maximal inhibitory concentration: > 100000 nM
Compound 4: a limit, no number; the forecaster's own chance of this, stated with the estimate: 60%; the middle value sits exactly at the limit.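

In this assay compound 4 gives > 100000 nM as a limit of the assay and not a number. For the compounds shown here, compound 1 also rests at a limit, so no step between compound 1 and compound 4 can be read: the limit of > 100000 nM in this assay, at which 2 of the 4 values shown sit. The compounds shown leave open whether trifluoromethyl in place of fluoro changes the result at all.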